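Replacing a Urea Tail with an Ethyl Ester Chain

The source may hold more compounds than are shown below. What is called first, only, known or untested is meant among the compounds shown, and "the series" means these compounds.

Measured so far:
- compound 1, `COc1ccc(-c2nc(/N=C(\N)N(C)C)sc2-c2ccc(OC)cc2)cc1`: 37 nM
- compound 2, `COc1ccc(-c2nc(CNC(C)=O)sc2-c2ccc(OC)cc2)cc1`: 15 nM
- compound 3, `COc1ccc(-c2nc(CNC(=O)NC(C)C)sc2-c2ccc(OC)cc2)cc1`: 42 nM

All three compounds share the same core and differ only in the group on one aromatic carbon. In a functional assay with Oryctolagus cuniculus as the target (a higher number here means a weaker inhibitor, a lower number a stronger inhibitor), compound 3 gives the highest of the three numbers. Its nearest neighbour is compound 1, and a 1.1-fold higher number from compound 1 to compound 3 (0.06 log units; within the scatter) stays within the scatter, so the two cannot be ordered. Against compound 2 the gap is real: a 2.8-fold higher number from compound 2 to compound 3 (0.45 log units; beyond the scatter). The other measured step, a 2.5-fold lower number from compound 1 to compound 2 (0.39 log units; beyond the scatter), is of similar modest size.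

Compound 4, `CCOC(=O)/C=C/c1nc(-c2ccc(OC)cc2)c(-c2ccc(OC)cc2)s1`, carries a new group at that same position: 2-(ethoxycarbonyl)ethenyl in place of ((isopropylcarbamoyl)amino)methyl on an aromatic carbon. Within the data shown here, no measured compound has an ester or a carbon-carbon double bond in this side chain, so none of the three steps bears directly on this change. What they do show is that swapping the group at this position has so far moved the numbers only modestly in either direction. On that basis a modest step is expected in this assay, with no clear direction. For compound 4 the estimated step is a 1.1-fold higher number from compound 3 to compound 4 (0.03 log units; within the scatter). Compound 4 is therefore expected to give about 45 nM, within a range from 14 nM to 140 nM.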

Compound 4, half-maximal inhibitory concentration: 20 nM
Estimate against measurement, compound 4: 2.3-fold (0.35 log units) above, and the stated range covers the measured number.
By their numbers in this assay, from the lowest: compounds 2, 4, 1 and 3 (each within the scatter of the next, the first and the last beyond it).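

In this assay the 2-(ethoxycarbonyl)ethenyl chain gives a real gain over ((isopropylcarbamoyl)amino)methyl, with a 2.1-fold lower number from compound 3 to compound 4 (0.32 log units; beyond the scatter) showing that this position tolerates a group with 0 hydrogen-bond donors, an ester and a carbon-carbon double bond. The new chain cannot be ordered against the two other groups, since a 1.3-fold higher number from compound 2 to compound 4 (0.12 log units; within the scatter) and a 1.9-fold lower number from compound 1 to compound 4 (0.27 log units; within the scatter) are both printed as within the scatter, and side chains of quite different make-up therefore land in the same narrow band of numbers. No measurement here bears on why the step from the urea chain occurs.

The ester, the double bond and the loss of the hydrogen-bond donors all arrive together in compound 4, and the compounds shown do not separate their contributions. Going by these compounds, the saturated 2-(ethoxycarbonyl)ethyl chain, the free carboxylic acid or a primary amide in place of the ethyl ester would each change just one of these features, and how any of them behaves at this position remains open.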